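Pairing two fused-ring anilines, then a third group

The compounds below may be only part of what the source reports. "The series", "measured", "known", "first", "only" and "open" are said of these compounds alone.

- compound 1 `Cn1ccc2cc(Nc3ncc4cc(S(=O)(=O)c5ccc(F)cc5F)c(=O)n(C)c4n3)ccc21`: 750 nM
- compound 2 `Cn1c(=O)c(S(=O)(=O)c2ccc(F)cc2F)cc2cnc(Nc3cnc4[nH]ccc4c3)nc21`: 750 nM

In a functional assay on K562 cells (Homo sapiens) for inhibition, read by trypan blue exclusion, with a stated time of 72 h (on this read-out lower numbers stand for stronger inhibition and higher numbers for weaker inhibition), compound 2 gives 750 nM, level with compound 1 at 750 nM. With only these two measured, the numbers set no order between them.

Compound 3 `Cn1c(=O)c(S(=O)(=O)c2ccc(F)cc2F)cc2cnc(Nc3ccc4c(c3)C(=O)C(=O)N4)nc21` differs from compound 2 as follows: a group of 11 heavy atoms (8 carbon, 1 nitrogen, 2 oxygen; one five-membered non-aromatic ring with 1 hetero atom, one six-membered aromatic ring of carbon only) in place of a group of 9 heavy atoms (7 carbon, 2 nitrogen; one five-membered aromatic ring with 1 hetero atom, one six-membered aromatic ring with 1 hetero atom), on a nitrogen on an aromatic ring. The core and the nitrogen carrying the group stay the same.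

For the measured compounds named here, one measured step bears on this change: no change at the digits printed from compound 1 to compound 2 (within the scatter). That step also replaced the group on this nitrogen, and it shows no movement beyond the scatter. Because of no change at the digits printed from compound 1 to compound 2 (within the scatter) there is no measured reason to expect a large shift, and the data give no direction. The evidence is thin, however. Neither compound 1 nor compound 2 carries a five-membered non-aromatic ring, and the series holds no measurement for such a group, so the range stays wide.

The estimated step is a 1.1-fold higher number from compound 2 to compound 3 (0.03 log units; within the scatter). For compound 3 the expected value is 800 nM, within an estimated range from 250 nM to 2500 nM.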

Compound 3, half-maximal inhibitory concentration: 30000 nM
Beside the measured number, compound 3's estimate is 38-fold (1.57 log units) below it; measured number above the stated range.
By their numbers in this assay, from the lowest: compounds 1 and 2 (each within the scatter of the next); then compound 3.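

For the compounds shown here, the position on the nitrogen on an aromatic ring is not indifferent to its group: the level pair, no change at the digits printed from compound 1 to compound 2 (within the scatter), covered only two groups that each hold a five-membered aromatic ring, whereas in this assay the group with a five-membered non-aromatic ring gives a 40-fold higher number from compound 2 to compound 3 (1.60 log units; beyond the scatter) and, against the other partner, a 40-fold higher number from compound 1 to compound 3 (1.60 log units; beyond the scatter). The two large steps agree in size and show the same rise from either starting group, so the earlier flat result does not extend to every fused bicyclic group at this nitrogen. No measurement available here accounts for the rise, and nothing in hand ties it to any one feature of the entering group.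

The entering group differs at once in its non-aromatic five-membered ring, its 2 oxygen atoms and its 2 double bonds outside aromatic rings, so a single step cannot separate these features, and a version keeping the same ring with only one carbonyl would be needed to do so. From the compounds shown here alone, how a simple phenyl group carrying an amine or a carboxylic acid would read at this nitrogen also stays open.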